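The compounds below may be only part of what the source reports. "The series", "measured", "known", "first", "only" and "open" are said of these compounds alone.

Working notes on the series. The three measured compounds share one core bearing a 2,2,2-trifluoro-1-hydroxy-1-(trifluoromethyl)ethyl group and differ at a single aromatic carbon. In an ADME assay (liver) for metabolic stability, with Liver microsome (Rattus norvegicus) as the target, using microsomes and NADPH, with a stated time of 30 min, tested at 1 uM (on this read-out lower numbers stand for slow clearance and higher numbers for fast clearance), compound 1 `Nc1ccc(S(=O)(=O)N2CCN(c3ncc(C(O)(C(F)(F)F)C(F)(F)F)cc3Br)CC2)cn1` gives 32 mL.min-1.g-1. Compound 2 `Nc1ccc(S(=O)(=O)N2CCN(c3ncc(C(O)(C(F)(F)F)C(F)(F)F)cc3C3CC3)CC2)cn1` gives 27 mL.min-1.g-1 in this assay, and a 1.2-fold lower number from compound 1 to compound 2 (0.07 log units; within the scatter). Compound 3 `CC(C)n1cc(-c2cc(C(O)(C(F)(F)F)C(F)(F)F)cnc2N2CCN(S(=O)(=O)c3ccc(N)nc3)CC2)cn1` gives 198 mL.min-1.g-1 in this assay, the highest of the three numbers: a 6.2-fold higher number from compound 1 to compound 3 (0.79 log units; beyond the scatter), and a 7.3-fold higher number from compound 2 to compound 3 (0.87 log units; beyond the scatter).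

Compound 4 `Nc1ccc(S(=O)(=O)N2CCN(c3ncc(C(O)(C(F)(F)F)C(F)(F)F)cc3-c3cccc4[nH]ncc34)CC2)cn1` is the next member and awaits measurement. The change from compound 3 is 1H-indazol-4-yl in place of 1-isopropyl-1H-pyrazol-4-yl on an aromatic carbon. The two steps into compound 3 bear on this: each replaced a small substituent with a five-membered aromatic ring with 2 hetero atoms and moved the number beyond the scatter in the upward direction. Compound 4 keeps a ring of that kind at the same carbon and adds a fused six-membered aromatic ring of carbon only, so no step beyond the scatter is expected in this assay. Compound 4 is estimated at 170 mL.min-1.g-1, in the range 70 mL.min-1.g-1 to 400 mL.min-1.g-1. The expected step is therefore a 1.2-fold lower number from compound 3 to compound 4 (0.07 log units; within the scatter).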

Compound 4, intrinsic clearance in microsomes: 93 mL.min-1.g-1
For compound 4 the middle estimate is 1.8-fold (0.26 log units) above the measured one, within the range that was stated.
By their numbers in this assay, from the lowest: compounds 2 and 1 (each within the scatter of the next); then compound 4; then compound 3.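

Exchange of 1-isopropyl-1H-pyrazol-4-yl for 1H-indazol-4-yl in this assay gives a 2.1-fold lower number from compound 3 to compound 4 (0.33 log units; beyond the scatter) at this carbon, so two substituents that both carry a five-membered aromatic ring with 2 hetero atoms are separated here. 1H-indazol-4-yl still stands above both small groups, with a 2.9-fold higher number from compound 1 to compound 4 (0.46 log units; beyond the scatter) in place of bromo and a 3.4-fold higher number from compound 2 to compound 4 (0.54 log units; beyond the scatter) in place of cyclopropyl, so among these compounds both ring-bearing substituents give higher numbers, though not equally high. No measured evidence is at hand on why the numbers fall in this order.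

The compounds shown cannot separate the part played in the step by the fused six-membered aromatic ring of carbon only from that of the added hydrogen-bond donor. On these data alone, whether a plain phenyl ring, an amine or a carboxylic acid at this carbon would fall with the small groups or with the ring-bearing substituents stays open.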